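The compounds below may be only part of what the source reports. "The series", "measured", "known", "first", "only" and "open" are said of these compounds alone.

Compound 1 `Cc1ccccc1-n1nc(C)c2c1NC(=O)[C@H](C)S[C@@H]2c1ccc(-c2cccc(C(=O)O)c2)cc1` is recorded in an assay on isolated protein for agonist activity at Bile acid receptor (Homo sapiens), read by AlphaScreen, with a stated time of 30 min (on this read-out lower numbers stand for an effect already at smaller amounts and higher numbers for an effect only at larger amounts of compound), as "not active" (no number reported), so no single number places it on the scale. Compound 2 `CCc1ccccc1-n1nc(C)c2c1NC(=O)[C@H](C)S[C@@H]2c1ccc(Oc2ccccc2)cc1` in this assay gives 1100 nM. Compound 3 `COc1cccc(Oc2ccc([C@H]3S[C@@H](C)C(=O)Nc4c3c(C)nn4-c3ccccc3C)cc2)c1` differs from compound 1 in one place: 3-methoxyphenoxy in place of 3-carboxyphenyl on an aromatic carbon. Within the data shown here, no measured pair shows this exact change, so the size of the step cannot be read from data; a move from no activity to a reported number is expected, because compound 2 in this assay gives 1100 nM. Compound 3 is therefore estimated at about 900 nM, with a range from 200 nM to 4000 nM.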

Compound 3, half-maximal effective concentration: 1700 nM
The estimate for compound 3 lay 1.9-fold (0.28 log units) below the measured number; low and high end bracket the measured number.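

No step can be read from compound 1 to compound 3: in this assay compound 1 has no number. What the 3-carboxyphenyl group does in this series stays open, and no evidence bears on a cause.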